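An Ester Swap After a Level Pair

This account rests on a few compounds, and the source may have more. Where it says the series, first, only, none or still open, it means among the compounds named here.

In a functional assay on K562 cells (Homo sapiens) for cytotoxicity, read by MTT assay, with a stated time of 72 h (a higher number here means a weaker inhibitor, a lower number a stronger inhibitor), compound 1 `C=C1C(=O)[C@@]23C(=O)OC[C@]4(C(=O)CCC(C)(C)[C@H]4C=O)[C@@H]2CC[C@@H]1[C@H]3OC(=O)CC` gives 1310 nM, and compound 2 `C=C1C(=O)[C@@]23C(=O)OC[C@]4(C(=O)CCC(C)(C)[C@H]4C=O)[C@@H]2CC[C@@H]1[C@H]3OC(=O)c1ccc([N+](=O)[O-])cc1` gives 1330 nM. These two numbers lie within the scatter of each other, so compound 2 stands level with compound 1 and the pair offers no ranking.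

Compound 3 `C=C1C(=O)[C@@]23C(=O)OC[C@]4(C(=O)CCC(C)(C)[C@H]4C=O)[C@@H]2CC[C@@H]1[C@H]3OC(=O)c1ccccc1Cl`, not yet measured, keeps the shared core and differs from compound 2 at one place: 2-chlorophenyl in place of 4-nitrophenyl on a carbonyl carbon. In plain terms, it carries 2-chlorophenyl in place of 4-nitrophenyl on a carbonyl carbon.

For the measured compounds named here, only one measured step bears on this change. In a 1.0-fold higher number from compound 1 to compound 2 (0.01 log units; within the scatter), 4-nitrophenyl replaced ethyl at the same place, and the number stayed within the scatter. Going by the values given here, that single step is thin evidence, and no measured compound carries 2-chlorophenyl. Still, it gives no reason to expect a real shift in either direction, so the change is expected to stay within the scatter, as an estimated 1.0-fold lower number from compound 2 to compound 3 (0.01 log units; within the scatter). For compound 3 the estimated value is 1300 nM, with an expected range of 700 nM to 2400 nM.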

Compound 3, half-maximal inhibitory concentration: 1220 nM
Compound 3: the middle estimate sits 1.1-fold (0.03 log units) above what was measured; measured number inside the range.
By their numbers in this assay, from the lowest: compounds 3, 1 and 2 (each within the scatter of the next).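

Two further steps now bear on this place on a carbonyl carbon in this assay: 2-chlorophenyl in place of 4-nitrophenyl gives a 1.1-fold lower number from compound 2 to compound 3 (0.04 log units; within the scatter), and 2-chlorophenyl in place of ethyl gives a 1.1-fold lower number from compound 1 to compound 3 (0.03 log units; within the scatter). Ethyl, 4-nitrophenyl and 2-chlorophenyl thus all stand level here, so the level reading no longer rests on a single pair, and losing the 2 hydrogen-bond acceptors of 4-nitrophenyl, which 2-chlorophenyl does not carry, goes with no step beyond the scatter. Nothing measured here accounts for this level reading.

The compounds shown leave open whether the reading would hold for quite different groups on this carbonyl carbon, such as an amine, a carboxylic acid or a longer chain. From the compounds shown here alone, all three compounds also keep the shared core unchanged, so whether this place stays just as level when that core is altered remains open too.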